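A few compounds are considered here, and "the series" means these few. Any claim that something is new, unique, unknown or untested is made for them only; others in the source may bear on it.

Measured so far:
- Compound 1, `CC1CCN(C2CCN(S(=O)(=O)c3cnc(Cl)s3)CC2)CC1`: 1800 nM
- Compound 2, `CC1CCN(C2CCN(S(=O)(=O)c3ccc(Cl)cc3Cl)CC2)CC1`: 1 nM

Both compounds share the same core and differ only in the ring attached to the sulfonyl sulfur. In a functional assay on DLD-1 cells (Homo sapiens) for antiproliferative activity, read by CellTiter-Glo, with a stated time of 72 h (on this read-out higher numbers stand for weaker inhibition and lower numbers for stronger inhibition), compound 1 gives 1800 nM, while compound 2 gives 1 nM, the lowest of the two numbers; the step is a 1800-fold lower number from compound 1 to compound 2 (3.26 log units; beyond the scatter), a large drop in the number when 2,4-dichlorophenyl replaces 2-chloro-1,3-thiazol-5-yl.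

Compound 3, `Cc1cc(Cl)cc(Cl)c1S(=O)(=O)N1CCC(N2CCC(C)CC2)CC1`, keeps the ring of compound 2 and adds one small change: methyl in place of hydrogen on an aromatic carbon. The methyl sits ortho to a large group and meta to two chloro groups.

Among the measured compounds shown here, no measured step bears directly on adding a methyl to this ring; the only step seen exchanges the whole ring, and it is of a very different kind. There is therefore no basis for expecting a shift beyond the scatter in this assay, in either direction, and compound 3 is expected to stay close to compound 2, with an expected step of a 1.5-fold higher number from compound 2 to compound 3 (0.18 log units; within the scatter).

Compound 3 is thus estimated at 1.5 nM in this assay, most likely between 0.4 nM and 6 nM.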

Compound 3, half-maximal inhibitory concentration: 0.6 nM
Beside the measured number, compound 3's estimate is 2.5-fold (0.40 log units) above it, within the range that was stated.
By their numbers in this assay, from the lowest: compounds 3 and 2 (each within the scatter of the next); then compound 1.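

In this assay, methyl in place of hydrogen on this aromatic carbon, ortho to a large group and meta to two chloro groups, gives a 1.7-fold lower number from compound 2 to compound 3 (0.22 log units; within the scatter) and so leaves compound 2 and compound 3 indistinguishable on this read-out. The earlier step, a 1800-fold lower number from compound 1 to compound 2 (3.26 log units; beyond the scatter), exchanged the whole ring and could say nothing about a single carbon added to the ring of compound 2. This result adds that one extra methyl at this position can be accommodated without losing the very low number of compound 2, so this carbon need not carry a hydrogen for the activity seen in these cells. Nothing available explains why the number stays where it does.

Open, as far as these compounds go, is how much more this position can take: an ethyl group, a methoxy group or an amine on the same carbon could behave like the methyl or could shift the number well beyond the scatter. Also open, from the compounds shown here alone, is how a methyl on this carbon would act alongside a single chloro group instead of two, since both compound 2 and compound 3 carry two.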